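The compounds below may be only part of what the source reports. "The series", "measured", "known", "first", "only" and "open" are said of these compounds alone.

Compound 1 `Cc1ccccc1-c1cnnc(NCc2cc(-c3ccccc3)[nH]n2)n1` is the starting point. In an ADME assay on CEM174 cells (Homo sapiens) for cytotoxicity (a lower number here means that less compound is tolerated, a higher number that more compound is tolerated), compound 1 gives > 10000 nM, which is a limit of the assay rather than a number. Compound 3 `Cc1cc(C#N)ccc1-c1cnnc(NCc2cc(-c3ccccc3)[nH]n2)n1` carries the change (cyano in place of hydrogen on an aromatic carbon). In this assay compound 3 gives > 10000 nM, again a limit. The step that the two limits leave unreadable from compound 1 to compound 3 therefore cannot be sized, because the limit of > 10000 nM in this assay, at which 3 of the 3 values shown sit, holds both ends. Compound 2 `Cc1ccccc1-c1cncc(NCc2cc(-c3ccccc3)[nH]n2)c1` rests on a different core; the difference between the two cores is not broken down here. In this assay compound 2 gives > 10000 nM, a limit. Compound 4 `Cc1cc(C#N)ccc1-c1cncc(NCc2cc(-c3ccccc3)[nH]n2)c1` applies the same change to compound 2, namely (cyano in place of hydrogen on an aromatic carbon). A step that the limit leaves unreadable from compound 2 to compound 4 is expected from compound 2 to compound 4, since every value seen so far sits at the limit of > 10000 nM in this assay, at which 3 of the 3 values shown sit. For compound 4 the expected value is 20000 nM, within 8000 nM to 60000 nM.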

Compound 4, half-maximal cytotoxic concentration: > 10000 nM
Compound 4 ended at the assay's limit; the forecaster's own chance of this, stated with the estimate: 85%; the middle value is on the limit's open side.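

No new step can be read from compound 2 to compound 4, since both values are limits: the limit of > 10000 nM in this assay, at which 4 of the 4 values shown sit.

The compounds shown leave open at what concentration any of the four becomes cytotoxic in this assay, and so whether cyano in place of hydrogen changes that on either core.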